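Clearance notes: from compound 3 to compound 4

A few compounds are considered here, and "the series" means these few. Any claim that something is new, unique, unknown or untested is made for them only; others in the source may bear on it.

The series holds compound 1 `COc1cc(OCc2ccnc(N)c2Cl)cc2sc(N[C@@H]3CCCC[C@H]3O)nc12`, compound 2 `COc1cc(OCc2ccnc(N)n2)cc2sc(N[C@@H]3CCCC[C@H]3O)nc12`, compound 3 `COc1cc(OCc2ccnc(Nc3ccn(C)n3)n2)cc2sc(N[C@H]3CCCC[C@@H]3O)nc12` and the unmeasured compound 4 `COc1cc(OCc2ccnc(Nc3cn(C)nn3)n2)cc2sc(N[C@H]3CCCC[C@@H]3O)nc12`. In an ADME assay on microsomes from liver (Homo sapiens) for pharmacokinetics, read by LC-MS, using NADPH, with a stated time of 45 min, tested at 1 uM (on this read-out higher numbers stand for fast clearance and lower numbers for slow clearance), compound 1 gives 38 mL/min/kg, compound 2 gives 10 mL/min/kg and compound 3 gives 17 mL/min/kg. Compound 3 therefore lies within the scatter of compound 2 and beyond the scatter on the lower side of compound 1.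

Compound 4 carries 1-methyl-1H-1,2,3-triazol-4-yl in place of 1-methyl-1H-pyrazol-3-yl on a nitrogen on an aromatic ring. The difference reads (1-methyl-1H-1,2,3-triazol-4-yl in place of 1-methyl-1H-pyrazol-3-yl on a nitrogen on an aromatic ring).

Among the compounds with values here, no measured step changes this group. Within the data shown here, the only step available, a 3.8-fold lower number from compound 1 to compound 2 (0.58 log units; beyond the scatter), is modest, lies beyond the scatter and concerns a different place in the molecule, so it is a loose guide to size and none to direction.

No shift beyond the scatter is therefore expected in this assay, and the estimated step is a 1.2-fold lower number from compound 3 to compound 4 (0.08 log units; within the scatter). The estimate for compound 4 is 14 mL/min/kg, with an expected range of 7 mL/min/kg to 28 mL/min/kg.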

Compound 4, clearance: 43 mL/min/kg
Estimate against measurement, compound 4: 3.1-fold (0.49 log units) below, and the stated range ends below it.
By their numbers in this assay, from the lowest: compounds 2 and 3 (each within the scatter of the next); then compounds 1 and 4 (each within the scatter of the next).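

In this assay the group on this nitrogen on an aromatic ring is not a silent place: 1-methyl-1H-1,2,3-triazol-4-yl in place of 1-methyl-1H-pyrazol-3-yl gives a 2.5-fold higher number from compound 3 to compound 4 (0.40 log units; beyond the scatter), although the heavy-atom count stays the same and only a ring carbon becomes nitrogen. Within the data shown here, the earlier measured step concerned a different place in the molecule, so this is the first reading of how clearance responds to a change here, and the number moves upward beyond the scatter. Nothing at hand bears on why the number rises.

Open, on these data alone, is whether the rise follows the extra ring nitrogen or how the nitrogens are arranged in the ring, which a phenyl or a 1-methyl-1H-imidazol-4-yl group on the same nitrogen could help separate. Also open, as far as these compounds go, is whether a step of this size would recur with the 2-amino-3-chloropyridin-4-yl group of compound 1 on the other side of the molecule.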